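Methyl for hydrogen on the anilino ring of compound 1

The compounds below may be only part of what the source reports. "The series", "measured", "known", "first", "only" and "open" are said of these compounds alone.

Measured so far:
Compound 1 `Fc1cccc(-c2nc(Nc3ccccc3)c3cc(F)ccc3n2)c1` gives 49700 nM in a functional assay on MCF7 cells (Homo sapiens) for cytotoxicity, read by MTT assay, with a stated time of 48 h; a higher number here means a weaker inhibitor, a lower number a stronger inhibitor.
Compound 2 `Nc1cccc(Nc2nc(-c3cccc(F)c3)nc3ccc(F)cc23)c1` gives only a limit in this assay, > 50000 nM.

Among the compounds with values here, compound 1 holds the only numerical value in this assay; the other value is a limit. Within the data shown here, the single measured step, amino in place of hydrogen on an aromatic carbon, reads a number no lower from compound 1 to compound 2 (the limit leaves the size open), its size not readable because of the limit of > 50000 nM in this assay, at which 1 of the 2 values shown sits.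

Compound 3 `Cc1ccc(Nc2nc(-c3cccc(F)c3)nc3ccc(F)cc23)cc1` differs from compound 1 by methyl in place of hydrogen on an aromatic carbon. Among the measured compounds shown here, no measured step has this change. For the measured compounds named here, the one step that bears on it at all, from compound 1 to compound 2, puts a different group at the same kind of place and is known only to give a number no lower, with no readable size. Compound 1 itself sits close to the limit. A step beyond the scatter in either direction cannot be supported from what is shown; the expectation is therefore a number near that of compound 1, with a real chance that only a limit is returned.

Compound 3 is estimated at 60000 nM, within 25000 nM to 150000 nM, which means an expected step of a 1.2-fold higher number from compound 1 to compound 3 (0.08 log units; within the scatter).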

Compound 3, half-maximal inhibitory concentration: > 50000 nM
Compound 3 gave a limit, no number; the forecaster's own chance of this, stated with the estimate: 55%; the middle value lies beyond the limit too.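

In this assay, methyl on the anilino ring, para to a large group, reads a number no lower from compound 1 to compound 3 (the limit leaves the size open), so compound 3 joins compound 2 in showing that a group added to this ring of compound 1 gives no lower number in the compounds shown. Compound 3 gives > 50000 nM, which is a limit and not a number. Neither the size of the methyl step nor any order between compound 2 and compound 3 can be read, because both sit at the assay's ceiling: the limit of > 50000 nM in this assay, at which 2 of the 3 values shown sit.

The compounds shown leave open whether any group on the anilino ring can give a number clearly lower than that of compound 1, for example a chlorine atom, a methoxy group or a carboxylic acid. They also leave open whether methyl and amino differ at all in this assay, as a readable comparison needs compounds that return numbers and not limits.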